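Working notes: from compound 3 to compound 4

A few compounds are considered here, and "the series" means these few. Any claim that something is new, unique, unknown or untested is made for them only; others in the source may bear on it.

Measured so far in a physicochemical assay for solubility, measured as kinetic solubility, at pH 7.4; a higher number here means a more soluble compound, a lower number a less soluble compound:
compound 1 `COc1cc(N2CCN(C(=O)C3CCC(O)CC3)CC2)ccc1Nc1nc(NC2CCCCC2)c2nc[nH]c2n1` gives 19000 nM
compound 2 `COc1cc(N2CCN(C(=O)N3CCC(O)C3)CC2)ccc1Nc1nc(NC2CCCCC2)c2nc[nH]c2n1` gives 19000 nM
compound 3 `COc1cc(N2CCC(C(=O)N3CCC(N(C)C)C3)CC2)ccc1Nc1nc(NC2CCCCC2)c2nc[nH]c2n1` gives 38000 nM

Compound 3 at 38000 nM lies within the scatter of both compound 1 and compound 2, so the three numbers do not separate. Compound 4 `COc1cc(N2CCC(CC(=O)N3CCC(N(C)C)C3)CC2)ccc1Nc1nc(NC2CCCCC2)c2nc[nH]c2n1` differs from compound 3 by ((3-(dimethylamino)pyrrolidin-1-yl)carbonyl)methyl in place of (3-(dimethylamino)pyrrolidin-1-yl)carbonyl on a saturated ring carbon, on a saturated ring carbon. For the measured compounds named here, no measured step covers this kind of change. Going by the values given here, the only measured step, no change at the digits printed from compound 1 to compound 2 (within the scatter), is a different exchange on a carbonyl carbon and bears on it only loosely. On that evidence, no step beyond the scatter is expected in this assay, in either direction. The estimated 1.2-fold lower number from compound 3 to compound 4 (0.07 log units; within the scatter) is therefore small. For compound 4 the expected value is 32000 nM, with an estimated range from 14000 nM to 65000 nM.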

Compound 4, solubility: 75000 nM
Beside the measured number, compound 4's estimate is 2.3-fold (0.37 log units) below it, and the stated range ends below it.
By their numbers in this assay, from the lowest: compounds 1, 2, 3 and 4 (each within the scatter of the next, the first and the last beyond it).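

In this assay, ((3-(dimethylamino)pyrrolidin-1-yl)carbonyl)methyl in place of (3-(dimethylamino)pyrrolidin-1-yl)carbonyl gives a 2.0-fold higher number from compound 3 to compound 4 (0.30 log units; within the scatter). For the compounds shown here, this is the first measured step at this saturated ring carbon, three ring bonds from the ring nitrogen, and it shows that the added methyl unit does not carry the read-out beyond the scatter. No measured evidence bears on a cause for this step. Still open, going by these compounds, is whether a longer chain before the same carbonyl, or a carboxylic acid in place of the amide, would stay within the scatter at this ring carbon.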